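The source may hold more compounds than are shown below. What is called first, only, known or untested is meant among the compounds shown, and "the series" means these compounds.

Compound 1 (`COc1ccc(-c2c[nH]c(=O)n2-c2cc(OC)c(OC)c(OC)c2)cc1OC`) gives only a limit in a functional assay on PC-3 cells (Homo sapiens) for cytotoxicity, read by MTT assay, with a stated time of 48 h (a higher number here means a weaker inhibitor, a lower number a stronger inhibitor), > 50000 nM. Compound 4 (`COc1ccc(-c2cn(C(C)=O)c(=O)n2-c2cc(OC)c(OC)c(OC)c2)cc1OC`) places acetyl in place of hydrogen on an aromatic nitrogen of the core: acetyl in place of hydrogen on an aromatic nitrogen. Among the measured compounds shown here, no measured step covers this change. Compound 2 (`COc1ccc(-c2cn(C(=O)Nc3cc(OC)c(OC)c(OC)c3)c(=O)n2-c2cc(OC)c(OC)c(OC)c2)cc1`), which also carries a carbonyl on that nitrogen, gives 49700 nM in this assay, and compound 3 (`COc1ccc(-c2cn(C(=O)Nc3cc(OC)c(OC)c(OC)c3)c(=O)n2-c2cc(OC)c(OC)c(OC)c2)cc1N`) gives 10000 nM. For the measured compounds named here, the one measured step, a 5.0-fold lower number from compound 2 to compound 3 (0.70 log units; beyond the scatter), is amino in place of hydrogen on an aromatic carbon, so it bears only indirectly and sets a modest scale. In this assay, little or no change beyond the scatter is therefore expected. The expected step is an at least 1.2-fold lower number from compound 1 to compound 4 (0.09 log units; that floor lies within the scatter). For compound 4 the estimate is 40000 nM, with an expected range of 12000 nM to 100000 nM.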

Compound 4, half-maximal inhibitory concentration: > 50000 nM
Compound 4 ended at the assay's limit (the forecaster's own chance of this, stated with the estimate: 55%); at least 1.2-fold (0.09 log units) between middle value and limit.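

No step can be read from compound 1 to compound 4, as both end at the assay's limit: the limit of > 50000 nM in this assay, at which 2 of the 4 values shown sit.

From the compounds shown here alone, whether acetyl in place of hydrogen on an aromatic nitrogen changes the read-out on the shared core remains open.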